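The source may hold more compounds than are shown below. What is called first, only, known or untested is meant among the compounds shown, and "the series" means these compounds.

Measured compounds:
- compound 1 `O=C(/C=C/c1cccc(NS(=O)(=O)c2ccc(Cl)cc2)c1)c1nc2ccccc2[nH]1`: 7450 nM
- compound 2 `Cc1ccccc1S(=O)(=O)Nc1cccc(/C=C/C(=O)c2nc3ccccc3[nH]2)c1`: 4060 nM
- compound 3 `Cc1cccc(S(=O)(=O)Nc2cccc(/C=C/C(=O)c3nc4ccccc4[nH]3)c2)c1`: 791 nM

These three share one core and differ only in the ring attached to the sulfonyl sulfur. In a functional assay on 143B cells (Homo sapiens) for antiproliferative activity, read by MTT assay, with a stated time of 48 h (on this read-out higher numbers stand for weaker inhibition and lower numbers for stronger inhibition), compound 3 gives the lowest number of the three: the step from compound 1 to compound 3 is a 9.4-fold lower number from compound 1 to compound 3 (0.97 log units; beyond the scatter), and the step from compound 2 to compound 3 is a 5.1-fold lower number from compound 2 to compound 3 (0.71 log units; beyond the scatter), both beyond the scatter, whereas a 1.8-fold lower number from compound 1 to compound 2 (0.26 log units; within the scatter) stays within it. Compound 4 `O=C(/C=C/c1cccc(NS(=O)(=O)c2cc(Cl)cc(Cl)c2)c1)c1nc2ccccc2[nH]1` has not yet been measured. It differs from compound 3 in one place: 3,5-dichlorophenyl in place of 3-methylphenyl on a sulfonyl sulfur. For the measured compounds named here, no measured step swaps methyl for chlorine at the same place on this ring, nor adds a second substituent. What the measured steps do show is that where the single substituent sits shifts the number by a modest amount, as seen in a 5.1-fold lower number from compound 2 to compound 3 (0.71 log units; beyond the scatter) and a 9.4-fold lower number from compound 1 to compound 3 (0.97 log units; beyond the scatter). Compound 4 keeps a substituent at the same place as compound 3 and adds another, so the expected step of a 1.9-fold higher number from compound 3 to compound 4 (0.28 log units; within the scatter) is small, with wide uncertainty. Compound 4 is therefore estimated at 1500 nM, within a range of 400 nM to 6000 nM.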

Compound 4, half-maximal inhibitory concentration: 5950 nM
The estimate for compound 4 lay 4.0-fold (0.60 log units) below the measured number; the range from low to high includes it.
By their numbers in this assay, from the lowest: compound 3; then compounds 2, 4 and 1 (each within the scatter of the next).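

In this assay, for the compounds shown here, the change from 3-methylphenyl to 3,5-dichlorophenyl on the sulfonyl sulfur costs a clear loss of activity (a 7.5-fold higher number from compound 3 to compound 4 (0.88 log units; beyond the scatter)), so this position does not accept every ring that resembles the one in compound 3. The new ring also cannot be told apart from the other two rings (a 1.5-fold higher number from compound 2 to compound 4 (0.17 log units; within the scatter); a 1.3-fold lower number from compound 1 to compound 4 (0.10 log units; within the scatter); both within the scatter), which leaves the 3-methylphenyl ring of compound 3 alone with the lowest number among these four compounds. No supporting data bear on why this happens.

Two things change together here, the kind of substituent and the number of substituents, so the compounds shown cannot separate them. Going by these compounds, a 3-chlorophenyl ring and a 3,5-dimethylphenyl ring would each change only one of the two, and both remain open.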